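Benzoyl in place of acetyl on the ring nitrogen

A few compounds are considered here, and "the series" means these few. Any claim that something is new, unique, unknown or untested is made for them only; others in the source may bear on it.

Measured so far:
compound 1 `COc1cc(C(F)(F)F)cc(C(F)(F)F)c1C(=O)NC1(c2ccccc2)CCCN(CC2CC2)C1` gives 380 nM in an assay on cells for inhibition of sodium- and chloride-dependent glycine transporter 1 (Homo sapiens); on this read-out lower numbers stand for an effect already at smaller amounts and higher numbers for an effect only at larger amounts of compound
compound 2 `COc1cc(C(F)(F)F)cc(C(F)(F)F)c1C(=O)NC1(c2ccccc2)CCCN(C(C)=O)C1` gives > 10000 nM in this assay

Compound 1 is the only one of the two with a number in this assay. For compound 2 the value is a limit of the assay, not a number; compound 2 therefore stands at the weak end of what this assay can report (the limit of > 10000 nM in this assay, at which 1 of the 2 values shown sits). Among the compounds with values here, the one measured step, an at least 26-fold higher number from compound 1 to compound 2 (1.42 log units; beyond the scatter), is large and beyond the scatter.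

Compound 3 `COc1cc(C(F)(F)F)cc(C(F)(F)F)c1C(=O)NC1(c2ccccc2)CCCN(C(=O)c2ccccc2)C1` differs from compound 2 by phenyl in place of methyl on a carbonyl carbon. Within the data shown here, it keeps the carbonyl on the amide-type nitrogen in the ring that compound 2 carries, so the only step that bears on it, an at least 26-fold higher number from compound 1 to compound 2 (1.42 log units; beyond the scatter), points towards compound 3 staying weak. Among the measured compounds shown here, nothing among the measured compounds shows what phenyl in place of methyl on that carbonyl carbon does, so no shift beyond the scatter is expected from compound 2 to compound 3, and the estimated step is a step that the limit leaves unreadable from compound 2 to compound 3. Compound 3 is therefore expected at about 15000 nM, within a range from 3000 nM to 80000 nM, most likely again reported only as a limit.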

Compound 3, half-maximal effective concentration: > 10000 nM
Compound 3: only a limit was reported; the forecaster's own chance of this, stated with the estimate: 70%; the middle value lies beyond the limit too.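

With benzoyl on the ring nitrogen, compound 3 gives > 10000 nM in this assay, and this value is a limit of the assay. Measured against the cyclopropylmethyl group, the change to benzoyl gives an at least 26-fold higher number from compound 1 to compound 3 (1.42 log units; beyond the scatter), so the loss of a measurable number at this position is no longer tied to acetyl alone and also holds with phenyl on the carbonyl carbon. The step from acetyl to benzoyl itself cannot be read, because compound 2 and compound 3 both rest on the same limit: the limit of > 10000 nM in this assay, at which 2 of the 3 values shown sit.

Going by these compounds, how far compound 2 and compound 3 lie beyond that limit stays open, and so does any ranking of the two acyl groups. The compounds shown also cannot separate the effect of having a carbonyl on the ring nitrogen from that of losing cyclopropylmethyl, a question that a benzyl group or a longer alkyl chain on the same nitrogen would bear on, since either would keep that nitrogen an amine while changing the group it carries.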